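This account rests on a few compounds, and the source may have more. Where it says the series, first, only, none or still open, it means among the compounds named here.

Measured compounds:
Compound 1, `CCc1nc(-c2ccc(Oc3ccnc(C(=O)NC)c3)cc2)no1`, gave 43700 nM.
Compound 2, `CCc1nc(-c2ccc(Oc3ccnc(C(=O)NC)c3)c(C)c2)no1`, gave 25200 nM.
Compound 3, `CC(C)c1nc(-c2ccc(Oc3ccnc(C(=O)N(C)C)c3)cc2)no1`, gave 9000 nM.

All three were read in an ADME assay on H1-HeLa cells (Homo sapiens) for cytotoxicity, read by MTT assay, with a stated time of 3 days; a lower number here means that less compound is tolerated, a higher number that more compound is tolerated. Compound 1 and compound 2 share one core and differ by methyl in place of hydrogen on an aromatic carbon. That change gave a 1.7-fold lower number from compound 1 to compound 2 (0.24 log units; within the scatter). Compound 3 is built on another core; the difference between the two cores is not broken down here. Compound 3 gave the lowest of the three numbers, and its gaps to compound 2 and to compound 1 both lie beyond the scatter.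

Compound 4, `Cc1cc(-c2noc(C(C)C)n2)ccc1Oc1ccnc(C(=O)N(C)C)c1`, has not yet been measured. It differs from compound 3 by methyl in place of hydrogen on an aromatic carbon. The surroundings are not identical to the earlier pair: there the methyl entered meta to a 5-ethyl-1,2,4-oxadiazol-3-yl group (7 heavy atoms), here meta to a 5-isopropyl-1,2,4-oxadiazol-3-yl group (8 heavy atoms), so this is the same kind of change, not the same change. Within the data shown here, for compound 4 the step is expected to be a 1.5-fold lower number from compound 3 to compound 4 (0.18 log units; within the scatter) in this assay, because the only precedent is a 1.7-fold lower number from compound 1 to compound 2 (0.24 log units; within the scatter). Compound 4 is therefore estimated at 6000 nM, within 3000 nM to 13000 nM.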

Compound 4, half-maximal cytotoxic concentration: 1400 nM
Compound 4: middle estimate off by 4.3-fold (0.63 log units), on the high side, and the stated range ends above it.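

In this assay, methyl in place of hydrogen on an aromatic carbon gave a 6.4-fold lower number from compound 3 to compound 4 (0.81 log units; beyond the scatter), and this step does not match the one seen on the other core: the same change on two cores in this assay, a 1.7-fold lower number (0.24 log units; within the scatter) from compound 1 to compound 2 and a 6.4-fold lower number (0.81 log units; beyond the scatter) from compound 3 to compound 4, 3.7-fold (0.57 log units) apart, beyond the scatter of two such steps. Among these compounds, the size of the step therefore did not carry from one core to the other, and only the step on the core of compound 3 lies beyond the scatter. What this does not show is which difference between the cores is responsible, as the two pairs differ both in the oxadiazole substituent, with a 5-ethyl-1,2,4-oxadiazol-3-yl group in one and a 5-isopropyl-1,2,4-oxadiazol-3-yl group in the other, and in the amide, and two pairs cannot separate these.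

The compounds shown include no pair that changes the oxadiazole substituent or the amide alone, so the contribution of each remains open. Also open, on these data alone, is how chlorine, methoxy or a longer chain such as ethyl would behave in place of the methyl on either core.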